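This account rests on a few compounds, and the source may have more. Where it says the series, first, only, none or still open, it means among the compounds named here.

Measured so far:
compound 1 `CCCCCCNc1nc(-c2ccccc2)nc2c1nnn2Cc1ccccc1`, 13200000 nM
compound 2 `Clc1ccccc1Cn1nnc2c(NC3CCC3)nc(-c3ccccc3)nc21`, 24000000 nM

In an assay on isolated protein for binding affinity to adenosine receptor A1 (Bos taurus) (a higher number here means a weaker inhibitor, a lower number a stronger inhibitor), compound 1 gives 13200000 nM and compound 2 gives 24000000 nM. The two numbers fall within the usual scatter of each other, so compound 2 stands level with compound 1 and neither is set apart. Compound 3 `CC(O)CNc1nc(-c2ccccc2)nc2c1nnn2Cc1ccccc1Cl` remains to be measured. It differs from compound 2 in one place: 2-hydroxypropyl in place of cyclobutyl on a nitrogen on an aromatic ring. Among the compounds with values here, no measured pair shows this change, so nothing in the set fixes its size; in this assay no step beyond the scatter is expected in either direction. For compound 3 the expected value is 20000000 nM, with a range from 5000000 nM to 80000000 nM. The expected step is a 1.2-fold lower number from compound 2 to compound 3 (0.08 log units; within the scatter).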

Compound 3, inhibition constant: 32000000 nM
For compound 3 the middle estimate is 1.6-fold (0.20 log units) below the measured one, within the range that was stated.
By their numbers in this assay, from the lowest: compounds 1, 2 and 3 (each within the scatter of the next, the first and the last beyond it).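

Cyclobutyl and 2-hydroxypropyl on this nitrogen on an aromatic ring give, in this assay, a 1.3-fold higher number from compound 2 to compound 3 (0.12 log units; within the scatter). This first one-place pair shows that, at this position, an open chain with a hydrogen-bond donor and acceptor reads level with a four-membered carbon ring that has neither. No measurement shown here accounts for this result. As far as these compounds go, whether a carboxymethyl or aminoethyl group on the same nitrogen would give a step beyond the scatter stays open. So does whether the same change reads alike with a different group elsewhere on the core.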